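The source may report more compounds than this note shows. Statements on the series, on what has been measured and on what is new or still open speak of the compounds shown alone.

Measured in an ADME assay on microsomes from liver (Homo sapiens) for metabolic stability, with a stated time of 30 min, tested at 1 uM; on this read-out higher numbers stand for a more stable compound and lower numbers for a less stable compound:

Compound 1 `CC[C@@H]1C(=O)N(C)c2cnc(-n3ccnc3-c3ccccc3)nc2N1[C@@H]1CCOC1`: 10%
Compound 2 `CC[C@@H]1C(=O)N(C)c2cnc(-n3ccnc3-c3ccccc3)nc2N1C1CCCC1`: 0%
Compound 3 `CC[C@@H]1C(=O)N(C)c2cnc(-n3ccnc3-c3ccc(F)cc3)nc2N1CCC(F)(F)F`: 27%

Of these three, compound 3 gives the highest number, 27%, and its gaps to compound 1 and compound 2 both lie beyond the scatter. Compound 4 `CC[C@@H]1C(=O)N(C)c2cnc(-n3ccnc3-c3ccccc3)nc2N1CCC(F)(F)F` keeps the group on nitrogen of compound 3 and changes only the aryl group: hydrogen in place of fluoro on an aromatic carbon. This is hydrogen in place of fluoro on an aromatic carbon, or 4-fluorophenyl to phenyl.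

Among the compounds with values here, no measured step covers this change. Within the data shown here, the one measured step, a number 10 percentage points lower from compound 1 to compound 2 (within the scatter), lies within the scatter and concerns the group on nitrogen. Compound 1 and compound 2 carry the phenyl of compound 4, but they also differ from compound 3 on nitrogen, so their gaps to compound 3 cannot be divided between the two sites. Their low values therefore support only a small expected fall, within the scatter, in this assay. The expected step is a number 7 percentage points lower from compound 3 to compound 4 (within the scatter). For compound 4 the estimated value is 20%, with an expected range from 7% to 35%.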

Compound 4, percent of the compound remaining: 0%
The estimate for compound 4 lay 20 percentage points above the measured number; measured number outside the range, below it.
By their numbers in this assay, from the lowest: compounds 2, 4 and 1 (each within the scatter of the next); then compound 3.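

In this assay, within the data shown here, the aryl group is varied here for the first time with the 3,3,3-trifluoropropyl group held on nitrogen, and hydrogen in place of fluoro gives a number 27 percentage points lower from compound 3 to compound 4 (beyond the scatter) and so a change beyond the scatter at this aromatic carbon. With phenyl held, changing the group on nitrogen gives no change at the digits printed from compound 2 to compound 4 (within the scatter) and a number 10 percentage points lower from compound 1 to compound 4 (within the scatter) so that cyclopentyl, oxolan-3-yl and 3,3,3-trifluoropropyl cannot be told apart in this series. Nothing available accounts for the effect of the fluoro group.

The compounds shown leave open whether fluoro has the same effect with cyclopentyl or oxolan-3-yl on nitrogen. They also leave open how a chloro, methoxy or nitrile group on the same aromatic carbon would compare with fluoro.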